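The source may hold more compounds than are shown below. What is called first, only, known or untested is meant among the compounds shown, and "the series" means these compounds.

Compound 1, `CCn1c(C(=O)NCCN)ccc1C(CC)(CC)c1ccc(OCCC(O)(CC)CC)c(C)c1`, is the stronger of the two numbers recorded here in a functional assay on PC-3 cells (Homo sapiens) for antiproliferative activity, read by MTT assay, with a stated time of 48 h (a lower number here means a stronger inhibitor, a higher number a weaker inhibitor), where compound 1 gives 2420 nM. Its nearest neighbour is compound 3, `CCOC(=O)CN(C)C(=O)c1ccc(C(CC)(CC)c2ccc(OCCC(O)(CC)CC)c(C)c2)n1CC`, which in this assay gives 7140 nM. Compound 2, `CCC(C)C(NC(=O)c1ccc(C(CC)(CC)c2ccc(OCCC(O)(CC)CC)c(C)c2)n1CC)C(=O)OC`, returns only a limit of this assay, > 50000 nM. Two measured steps start from compound 1: a 3.0-fold higher number from compound 1 to compound 3 (0.47 log units; beyond the scatter), and an at least 20-fold higher number from compound 1 to compound 2 (1.31 log units; beyond the scatter), the latter resting on (the limit of > 50000 nM in this assay, at which 1 of the 3 values shown sits).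

Compound 4, `CCn1c(C(=O)N(C)CC(=O)O)ccc1C(CC)(CC)c1ccc(OCCC(O)(CC)CC)c(C)c1`, differs from compound 1 by (carboxymethyl)(methyl)amino in place of (2-aminoethyl)amino on a carbonyl carbon. The closest measured precedent is the step to compound 3, which carries the same methylamino arm but closes it with an ester rather than the free acid of compound 4; that step was a 3.0-fold higher number from compound 1 to compound 3 (0.47 log units; beyond the scatter). The other step, an at least 20-fold higher number from compound 1 to compound 2 (1.31 log units; beyond the scatter), also runs toward a higher number. Compound 4 is therefore expected to fall off from compound 1 by about a 5.0-fold higher number from compound 1 to compound 4 (0.70 log units; beyond the scatter). The value of compound 4 in this assay is estimated at 12000 nM, within the range 3500 nM to 50000 nM.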

Compound 4, half-maximal inhibitory concentration: 2250 nM
Compound 4: the middle estimate sits 5.3-fold (0.73 log units) above what was measured; measured number outside the range, below it.
By their numbers in this assay, from the lowest: compounds 4 and 1 (each within the scatter of the next); then compound 3. At a limit, above all of these: compound 2.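

Setting (carboxymethyl)(methyl)amino in place of (2-aminoethyl)amino on a carbonyl carbon gives a 1.1-fold lower number from compound 1 to compound 4 (0.03 log units; within the scatter) in this assay, so at this position the carboxylic acid arm and the amine arm cannot be told apart. With hydrogen in place of ethyl on an oxygen next to a carbonyl group, the step is a 3.2-fold lower number from compound 3 to compound 4 (0.50 log units; beyond the scatter), which shows that the methylamino arm as such does not carry the loss seen with the ethyl ester. The remaining step, an at least 22-fold lower number from compound 2 to compound 4 (1.34 log units; beyond the scatter), has a limit of the assay at one end and gives only a bound: the limit of > 50000 nM in this assay, at which 1 of the 4 values shown sits.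

The compounds shown leave open whether a longer chain ending in a carboxylic acid would read the same. They also leave open what the free carboxylic acid of the branched arm of compound 2 would give.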